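This account rests on a few compounds, and the source may have more. Where it says the series, first, only, none or still open, it means among the compounds named here.

Working notes on the series, values in a functional assay on PC-3 cells (Homo sapiens) for cytotoxicity, read by sulforhodamine B assay, with a stated time of 48 h; a higher number here means a weaker inhibitor, a lower number a stronger inhibitor:
compound 1 `C[C@H]1CC[C@@H]2[C@@H](OC(=O)[C@]23CC(c2ccc(Cl)cc2)=NO3)[C@]2(C)C(=O)C=C[C@@]12O`: 49000 nM
compound 2 `C[C@H]1CC[C@@H]2[C@@H](OC(=O)[C@]23CC(c2ccccc2)=NO3)[C@]2(C)C(=O)C=C[C@@]12O`: 46000 nM
compound 3 `C[C@H]1CC[C@@H]2[C@@H](OC(=O)[C@]23CC(c2ccccc2F)=NO3)[C@]2(C)C(=O)C=C[C@@]12O`: 8200 nM

Compound 3 has the lowest number of the three, at 8200 nM. The next structure is compound 4 `C[C@H]1CC[C@@H]2[C@@H](OC(=O)[C@]23CC(c2ccc(F)cc2)=NO3)[C@]2(C)C(=O)C=C[C@@]12O`, reached by 4-fluorophenyl in place of 2-fluorophenyl on a carbon with a double bond to nitrogen.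

Going by the values given here, three measured steps bear on this change. Fluoro in place of hydrogen on an aromatic carbon gives a 5.6-fold lower number from compound 2 to compound 3 (0.75 log units; beyond the scatter), and the swap from 4-chlorophenyl to 2-fluorophenyl gives a 6.0-fold lower number from compound 1 to compound 3 (0.78 log units; beyond the scatter). Hydrogen in place of chloro gives a 1.1-fold lower number from compound 1 to compound 2 (0.03 log units; within the scatter), so the 4-chlorophenyl and the plain phenyl do not separate in this assay. Among the compounds with values here, no measured compound yet carries 4-fluorophenyl, so the gain seen with 2-fluorophenyl is expected to be mostly lost, though perhaps not entirely.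

The expected change is a 3.7-fold higher number from compound 3 to compound 4 (0.56 log units; beyond the scatter), towards a higher number and of modest size. Compound 4 is estimated at 30000 nM, with an expected range of 12000 nM to 65000 nM.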

Compound 4, half-maximal inhibitory concentration: 27000 nM
Compound 4: middle estimate off by 1.1-fold (0.05 log units), on the high side; the measured number falls inside the stated range.
By their numbers in this assay, from the lowest: compound 3; then compounds 4, 2 and 1 (each within the scatter of the next).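

In this assay, moving the fluoro from 2-fluorophenyl to 4-fluorophenyl on the same carbon gives (a 3.3-fold higher number from compound 3 to compound 4 (0.52 log units; beyond the scatter)), so among these compounds the lower number depends on where the fluoro sits and not only on its presence on the ring. Going by these compounds alone, the 4-fluorophenyl does not separate from the plain phenyl (a 1.7-fold lower number from compound 2 to compound 4 (0.23 log units; within the scatter)) or from the 4-chlorophenyl (a 1.8-fold lower number from compound 1 to compound 4 (0.26 log units; within the scatter)), which leaves 2-fluorophenyl as the only aryl group here that stands apart. No measurement at hand accounts for the difference between the two fluorophenyl groups.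

As far as these compounds go, it remains open whether a chloro, a methoxy or an amine in the ring place held by fluoro in 2-fluorophenyl would keep the number of compound 3 (8200 nM). From the compounds shown here alone, it also remains open whether the fluoro itself matters there, or whether any group in that place would do the same.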